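The source may hold more compounds than are shown below. What is called first, only, known or untested is meant among the compounds shown, and "the series" means these compounds.

Compound 2 `CCCCS(=O)(=O)Nc1ccc(C/N=C(\S)NCc2ccc(C(C)(C)C)cc2)cc1` gives 4100 nM in a functional assay for antagonist activity at Vanilloid receptor (Rattus norvegicus) (a lower number here means a stronger inhibitor, a higher number a weaker inhibitor), the highest of the two numbers recorded, while compound 1 `CCS(=O)(=O)Nc1ccc(C/N=C(\S)NCc2ccc(C(C)(C)C)cc2)cc1` gives 1300 nM. Going by the values given here, the step of a 3.2-fold higher number from compound 1 to compound 2 (0.50 log units; beyond the scatter) is the only measured comparison that bears on the sulfonyl substituent. Compound 3 `CC(C)S(=O)(=O)Nc1ccc(C/N=C(\S)NCc2ccc(C(C)(C)C)cc2)cc1` carries the change (isopropyl in place of butyl on a sulfonyl sulfur), so the chain on the sulfonyl sulfur is shortened rather than lengthened. Since lengthening it raised the number in the step from compound 1 to compound 2, a lower number is expected for compound 3, of modest size, a 2.1-fold lower number from compound 2 to compound 3 (0.31 log units; beyond the scatter), giving an estimate for compound 3 of 2000 nM, between 900 nM and 4500 nM.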

Compound 3, half-maximal inhibitory concentration: 3800 nM
Compound 3: middle estimate off by 1.9-fold (0.28 log units), on the low side; measured number inside the range.
By their numbers in this assay, from the lowest: compound 1; then compounds 3 and 2 (each within the scatter of the next).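

Replacing butyl with isopropyl on the sulfonyl sulfur gives a 1.1-fold lower number from compound 2 to compound 3 (0.03 log units; within the scatter), so in this assay these two groups cannot be told apart. Branching the ethyl chain gives a 2.9-fold higher number from compound 1 to compound 3 (0.47 log units; beyond the scatter), so the higher number is not confined to a lengthened straight chain; a single added methyl is enough. No measurement shown here explains this result.

Going by these compounds, whether methyl or a ring such as cyclopropyl on the sulfonyl sulfur would match compound 1 remains open. So does the effect of a longer chain or of an amine at this position.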